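The compounds below may be only part of what the source reports. "The series", "measured", "known", "first", "only" and "open" are said of these compounds alone.

Compound 1 `COc1cccc(CNCc2c(C(=O)O)n(Cc3ccc(C)cc3)c3ccccc23)c1`: 21500 nM
Compound 2 `COc1ccc(Cn2c(C(=O)O)c(CNCc3cccc(OC)c3)c3ccccc32)cc1`: 52900 nM
Compound 3 `COc1cccc(CNCc2c(C(=O)O)n(Cc3ccc(O)cc3)c3ccccc23)c1`: a limit, > 50000 nM

Of the compounds shown here, three sharing one core have been tested in a functional assay on Bel-7402 cells (Homo sapiens) for antiproliferative activity, read by MTT assay, with a stated time of 72 h; on this read-out lower numbers stand for stronger inhibition and higher numbers for weaker inhibition. Compound 2 stands highest of the two numbers shown, meaning the weaker of the two; the nearest is compound 1, and the step is a 2.5-fold higher number from compound 1 to compound 2 (0.39 log units; beyond the scatter). Compound 3 gives only a limit in this assay (the limit of > 50000 nM in this assay, at which 1 of the 3 values shown sits), so the step that the limit leaves unreadable from compound 2 to compound 3 cannot be read, and an at least 2.3-fold higher number from compound 1 to compound 3 (0.36 log units; beyond the scatter) is known only as a lower bound.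

Compound 4 `COc1ccc(Cn2c(C(=O)O)c(CNCc3cccc(OC)c3)c3ccc(C(F)F)cc32)cc1` is not yet measured. It differs from compound 2 by difluoromethyl in place of hydrogen on an aromatic carbon. Within the data shown here, none of the measured steps touches this ring of the core: they all swap methyl, methoxy and hydroxy on a different aromatic ring, and those swaps were modest where readable. Among the measured compounds shown here, no measured step therefore bears directly on this change, and the safest expectation is a step that stays within the scatter, with some chance that the assay again reports only a limit. Compound 4 is estimated at 45000 nM in this assay, with a range from 18000 nM to 110000 nM. For compound 4 the expected step is a 1.2-fold lower number from compound 2 to compound 4 (0.07 log units; within the scatter).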

Compound 4, half-maximal inhibitory concentration: > 50000 nM
Compound 4: only a limit was reported; the forecaster's own chance of this, stated with the estimate: 35%; middle value at least 1.1-fold (0.04 log units) from the limit.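

In this assay compound 4 gives only a limit, > 50000 nM, so no step from compound 2 to compound 4 can be read: the limit of > 50000 nM in this assay, at which 2 of the 4 values shown sit.

The compounds shown leave open whether difluoromethyl in place of hydrogen on an aromatic carbon of the shared core changes the number at all, and in which direction.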